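Removing one methyl from the side chain of compound 3

The source may hold more compounds than are shown below. What is called first, only, known or untested is meant among the compounds shown, and "the series" means these compounds.

Compound 1 `COC(=O)[C@@H](NC(=O)CSC1=CC(=O)c2cccc(OC)c2C1=O)C(C)C` gives 45000 nM here
Compound 2 `COC(=O)[C@@H](NC(=O)CSC1=C(C)C(=O)c2ccccc2C1=O)C(C)C` gives 16000 nM here
Compound 3 `CC[C@H](C)[C@H](NC(=O)CSC1=C(OC)C(=O)c2ccccc2C1=O)C(=O)OC` gives 60000 nM here

All three numbers come from a functional assay on SAS cells (Homo sapiens) for cytotoxicity, read by MTT assay, with a stated time of 48 h (on this read-out lower numbers stand for stronger inhibition and higher numbers for weaker inhibition), as the read-out. Compound 3 has the highest number of the three, but its gap to compound 1 stays within the scatter, while compound 2 lies lower, beyond the scatter. Compound 4 `COC(=O)[C@@H](NC(=O)CSC1=C(OC)C(=O)c2ccccc2C1=O)C(C)C` changes sec-butyl to isopropyl (hydrogen in place of methyl on a saturated chain carbon, three bonds along the chain from an amide-type nitrogen and a carbonyl carbon), which puts hydrogen in place of methyl on a saturated chain carbon. Going by the values given here, no measured pair shows this change alone. The change is small, and a 1.3-fold lower number from compound 3 to compound 4 (0.12 log units; within the scatter) is expected to stay within the scatter. Compound 4 is estimated at 45000 nM (expected range 20000 nM to 90000 nM).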

Compound 4, half-maximal inhibitory concentration: 56000 nM
The estimate for compound 4 lay 1.2-fold (0.09 log units) below the measured number; the range from low to high includes it.
By their numbers in this assay, from the lowest: compound 2; then compounds 1, 4 and 3 (each within the scatter of the next).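

In this assay, going from sec-butyl to isopropyl gives a 1.1-fold lower number from compound 3 to compound 4 (0.03 log units; within the scatter) and so shows that this methyl on the saturated chain carbon makes no measurable difference here. Going by these compounds alone, compound 4 also opens the first one-place comparison on the double-bonded ring carbon, where methoxy in place of methyl gives a 3.5-fold higher number from compound 2 to compound 4 (0.54 log units; beyond the scatter) and the number clearly moves. No measured evidence accounts for either result. Going by these compounds, it remains open how an amine or a chlorine atom on that ring carbon would read, and whether a longer chain in place of isopropyl would change the number.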